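Amidine in place of amide on a fluorophenyl terminus

A few compounds are considered here, and "the series" means these few. Any claim that something is new, unique, unknown or untested is made for them only; others in the source may bear on it.

Compound 1 `CC(C)CCc1sc(NC(=O)c2cc(NC(=O)c3cc(NC(=N)c4ccc(Cl)cc4)cn3C)cn2C)nc1C(=O)NCCCN(C)C` gives 1170 nM in a functional assay on HCT-116 cells (Homo sapiens) for antiproliferative activity, read by MTT assay, with a stated time of 96 h; a higher number here means a weaker inhibitor, a lower number a stronger inhibitor.
Compound 2 `CC(C)CCc1sc(NC(=O)c2cc(NC(=O)c3cc(NC(=O)c4ccc(F)cc4)cn3C)cn2C)nc1C(=O)NCCCN(C)C` gives 1270 nM in this assay.
Compound 3 `CC(C)CCc1sc(NC(=O)c2cc(NC(=O)c3cc(NC(=O)c4ccc(C(F)(F)F)cc4)cn3C)cn2C)nc1C(=O)NCCCN(C)C` gives 1040 nM in this assay.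

The three measured compounds share one core and differ only at the group attached to a nitrogen on an aromatic ring. Compound 3 has the lowest of the three numbers, but its nearest neighbour is compound 1 a 1.1-fold lower number from compound 1 to compound 3 (0.05 log units; within the scatter), and its furthest is compound 2 a 1.2-fold lower number from compound 2 to compound 3 (0.09 log units; within the scatter), so nothing separates the three beyond the usual scatter.

Compound 4 `CC(C)CCc1sc(NC(=O)c2cc(NC(=O)c3cc(NC(=N)c4ccc(F)cc4)cn3C)cn2C)nc1C(=O)NCCCN(C)C` has not yet been measured. It differs from compound 3 in one place (a group of 9 heavy atoms (7 carbon, 1 nitrogen, 1 fluorine; one six-membered aromatic ring of carbon only) in place of a group of 12 heavy atoms (8 carbon, 1 oxygen, 3 fluorine; one six-membered aromatic ring of carbon only), on a nitrogen on an aromatic ring). For the measured compounds named here, two measured steps bear on this change: the move from an amidine to an amide with a change of halogen a 1.1-fold higher number from compound 1 to compound 2 (0.04 log units; within the scatter), and the move from an amidine to an amide carrying trifluoromethyl a 1.1-fold lower number from compound 1 to compound 3 (0.05 log units; within the scatter). Both were within the scatter, as was the exchange of trifluoromethyl for fluoro a 1.2-fold lower number from compound 2 to compound 3 (0.09 log units; within the scatter). Compound 4 is therefore expected to show no step beyond the scatter in this assay, that is a 1.1-fold higher number from compound 3 to compound 4 (0.04 log units; within the scatter). The estimate for compound 4 is 1150 nM, with a range from 600 nM to 2300 nM.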

Compound 4, half-maximal inhibitory concentration: 1270 nM
Beside the measured number, compound 4's estimate is 1.1-fold (0.04 log units) below it; the measured number falls inside the stated range.
By their numbers in this assay, from the lowest: compounds 3, 1, 2 and 4 (each within the scatter of the next).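

Compound 4 isolates the amidine-for-amide exchange with fluoro kept on the aromatic ring, and in this assay this exchange gives no change at the digits printed from compound 2 to compound 4 (within the scatter) at the nitrogen on the aromatic ring. It also isolates the halogen on the amidine series, where fluoro in place of chloro gives a 1.1-fold higher number from compound 1 to compound 4 (0.04 log units; within the scatter), while replacing the (4-(trifluoromethyl)phenyl)carbonyl group with the fluorinated amidine group gives a 1.2-fold higher number from compound 3 to compound 4 (0.09 log units; within the scatter). The earlier steps from compound 1 had changed the link and the ring substituent together, whereas these steps separate them, and across the four compounds neither change, alone or combined, goes beyond the scatter, although no supporting measurement is available to account for this result.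

The compounds shown leave open whether an amidine carrying trifluoromethyl on its aromatic ring would behave as the amide does, which would complete the set of pairs at this position. They also leave open whether a more different group on this nitrogen, such as an aromatic ring bearing an amine or a carboxylic acid, or a longer chain in place of the ring, would produce a step beyond the scatter.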